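Chloro to methyl on the benzoyl ring: compound 4 expected

This account rests on a few compounds, and the source may have more. Where it says the series, first, only, none or still open, it means among the compounds named here.

Measured compounds in an assay on CHO cells for displacement of a labelled ligand from adenosine receptor A3 (Homo sapiens), read by scintillation counting, tested at 10 uM; a lower number here means less inhibition, a higher number more inhibition at the concentration tested (going by the name of the read-out):
compound 1 `Cc1cccc(-c2sc(N)c(C(=O)c3ccc(Cl)cc3)c2CC(C)(C)C)c1` 1%
compound 2 `Cc1ccc(C(=O)c2c(N)sc(Br)c2CC(C)(C)C)cc1` 1%
compound 3 `COc1ccc(-c2sc(N)c(C(=O)c3ccc(Cl)cc3)c2CC(C)(C)C)cc1` 2%

All three compounds give essentially no inhibition, and compound 3 sits within the usual scatter of both compound 1 and compound 2. Among the measured compounds shown here, the one single-point step, a number 1 percentage points higher from compound 1 to compound 3 (within the scatter), changed a different part of the molecule and stayed within the scatter.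

Compound 4 `COc1ccc(-c2sc(N)c(C(=O)c3ccc(C)cc3)c2CC(C)(C)C)cc1` differs from compound 3 by methyl in place of chloro on an aromatic carbon. For the measured compounds named here, no measured step concerns a change at this position, so nothing in the data points to a shift in either direction. Since every measured compound shows the same low level, compound 4 is expected to show no step beyond the scatter, no change at the digits printed from compound 3 to compound 4 (within the scatter). The estimate for compound 4 is 2%, with a range from -6% to 10%.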

Compound 4, a percentage reported as inhibition, at one concentration (the size of the read-out at that concentration, not a potency): 5%
The estimate for compound 4 lay 3 percentage points below the measured number, and the stated range covers the measured number.
By their numbers in this assay, from the lowest: compounds 1, 2, 3 and 4 (each within the scatter of the next).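

In this assay, among the compounds shown here, the first change at this position, 4-chlorophenyl to 4-methylphenyl, gives a number 3 percentage points higher from compound 3 to compound 4 (within the scatter) and leaves the compound at the same low level. With 4-methoxyphenyl in place of bromo on the other aromatic carbon, there is a number 4 percentage points higher from compound 2 to compound 4 (within the scatter) and the level again stays low. Nothing available explains or bears on these small numbers. Still open, as far as these compounds go, is whether an amine or a carboxylic acid in place of the methyl would move the number beyond the scatter.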